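Thiophen-2-yl in place of 2,4-dihydroxyphenyl

The compounds below may be only part of what the source reports. "The series", "measured", "known", "first", "only" and "open" are said of these compounds alone.

For the measured compounds named here, in a functional assay on MDA-MB-231 cells (Homo sapiens) for inhibition, read by MTT assay, with a stated time of 48 h (a higher number here means a weaker inhibitor, a lower number a stronger inhibitor), compound 3 `COc1cc(-c2cc(-c3ccc(O)cc3O)nc(-c3ccccc3)n2)cc(OC)c1OC` gives 810 nM, the lowest number among the compounds measured so far. Compound 2 `COc1cc(-c2cc(-c3cccc(O)c3)nc(-c3ccccc3)n2)cc(OC)c1OC` gives 1990 nM, and the difference between them is modest: a 2.5-fold lower number from compound 2 to compound 3 (0.39 log units; beyond the scatter). Compound 1 `COc1cc(-c2cc(-c3ccc(Cl)cc3)nc(-c3ccccc3)n2)cc(OC)c1OC` gives > 25000 nM, which is a limit of the assay and not a number.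

The change under review leads to compound 4 `COc1cc(-c2cc(-c3cccs3)nc(-c3ccccc3)n2)cc(OC)c1OC`, with thiophen-2-yl in place of 2,4-dihydroxyphenyl on an aromatic carbon. All three measured steps concern this same place on the shared core. The two large ones are an at least 12-fold lower number from compound 1 to compound 2 (1.09 log units; beyond the scatter) and an at least 30-fold lower number from compound 1 to compound 3 (1.48 log units; beyond the scatter). In this small set, compound 2 and compound 3 carry hydroxy groups and give numbers, while compound 1 carries 4-chlorophenyl and reaches the limit. Going by the values given here, no compound goes against this, but three compounds make thin evidence, and thiophen-2-yl has not been tested here.

Compound 4 loses both hydroxy groups, so it is read as closer to compound 1 than to compound 3, though it may not reach the limit. In this assay, the expected change is large and towards a higher number: a 9.9-fold higher number from compound 3 to compound 4 (0.99 log units; beyond the scatter). For compound 4 the estimated value is 8000 nM, with an expected range of 2000 nM to 25000 nM.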

Compound 4, half-maximal inhibitory concentration: 5110 nM
For compound 4 the middle estimate is 1.6-fold (0.19 log units) above the measured one, within the range that was stated.
By their numbers in this assay, from the lowest: compound 3; then compound 2; then compound 4. At a limit, above all of these: compound 1.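

In this assay, thiophen-2-yl, with 0 hydrogen-bond donors, still gives a number, an at least 4.8-fold lower number from compound 1 to compound 4 (0.68 log units; beyond the scatter), so compound 4 goes against the earlier split in which only the hydroxy-bearing groups gave numbers. The hydroxy groups still stand on the lower side at this position, with a 2.6-fold higher number from compound 2 to compound 4 (0.41 log units; beyond the scatter) for the 3-hydroxyphenyl of compound 2 and a 6.3-fold higher number from compound 3 to compound 4 (0.80 log units; beyond the scatter) for the 2,4-dihydroxyphenyl of compound 3, so dropping them costs potency without abolishing a measurable value. Compound 1 remains a limit and not a number, which makes its step to compound 4 a bound only: the limit of > 25000 nM in this assay, at which 1 of the 4 values shown sits.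

Each step to compound 4 changes the ring and its substituents together, so the part played by the five-membered ring with sulfur cannot be separated from the loss of the hydroxy groups, and an unsubstituted phenyl, a methoxyphenyl or an aminophenyl at this position would be needed to tell them apart. On these data alone, the other places on the shared core stay the same throughout, so how far this ordering holds with a different group at those places remains open.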